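This account rests on a few compounds, and the source may have more. Where it says the series, first, only, none or still open, it means among the compounds named here.

Measured so far in a functional assay on A549 cells (Homo sapiens) for inhibition, read by MTT assay, with a stated time of 72 h; a lower number here means a stronger inhibitor, a higher number a weaker inhibitor:
compound 1 `Cc1ccccc1N1CCN(C(=S)N/N=C2\C(=O)Nc3ccc(Cl)cc32)CC1`: 6520 nM
compound 2 `O=C1Nc2ccc(Cl)cc2/C1=N/NC(=S)N1CCN(c2ccc(F)cc2)CC1`: 8900 nM

Among the compounds with values here, compound 2 gives the higher of the two numbers measured so far, but its gap to compound 1 is within the scatter, so the two values cannot be ordered. Within the data shown here, the only step measured, a 1.4-fold higher number from compound 1 to compound 2 (0.14 log units; within the scatter), exchanged one substituted phenyl on the ring nitrogen for another and stayed within the scatter.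

Compound 3 `O=C1Nc2ccc(Cl)cc2/C1=N/NC(=S)N1CCN(c2ccccc2F)CC1` is still to be measured. It differs from compound 2 as follows: 2-fluorophenyl in place of 4-fluorophenyl on an amine nitrogen in a ring. Among the measured compounds shown here, this is again an exchange of one substituted phenyl for another on the same ring nitrogen, so the measured step from compound 1 to compound 2 is the closest precedent, and it was within the scatter. No step beyond the scatter is therefore expected for compound 3; the expected step is a 1.2-fold lower number from compound 2 to compound 3 (0.07 log units; within the scatter). The estimate for compound 3 in this assay is 7500 nM, with a range from 3500 nM to 16000 nM.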

Compound 3, half-maximal inhibitory concentration: 10500 nM
The estimate for compound 3 lay 1.4-fold (0.15 log units) below the measured number, and the stated range covers the measured number.
By their numbers in this assay, from the lowest: compounds 1, 2 and 3 (each within the scatter of the next).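

In this assay, the exchange of 4-fluorophenyl for 2-fluorophenyl on the amine nitrogen in the ring gives a 1.2-fold higher number from compound 2 to compound 3 (0.07 log units; within the scatter) and stays within the scatter, so the two fluorophenyl isomers cannot be ordered. The pair that carries fluoro in place of methyl on an aromatic carbon gives a 1.6-fold higher number from compound 1 to compound 3 (0.21 log units; within the scatter) and also stays within the scatter, so that exchange cannot be told apart from repeat variation either. No evidence is available that bears on these results.

Still open, on these data alone, is whether a phenyl carrying a methoxy, an amine or a carboxylic acid, or a benzyl or pyridyl on the same ring nitrogen, would give a step beyond the scatter. As far as these compounds go, the chloro on the shared core is also constant across the three compounds, so its contribution remains unknown.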